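Halogenated benzamides on a shared dimethoxyquinazoline core

The source may report more compounds than this note shows. Statements on the series, on what has been measured and on what is new or still open speak of the compounds shown alone.

Measured so far in a functional assay on HepG2 cells (Homo sapiens) for inhibition, read by MTT assay; on this read-out higher numbers stand for weaker inhibition and lower numbers for stronger inhibition:
- compound 1, `COc1cc2ncnc(Nc3ccc(NC(=O)c4ccccc4C)cc3)c2cc1OC`: 15000 nM
- compound 2, `COc1cc2ncnc(Nc3ccc(NC(=O)c4ccc(F)cc4)cc3)c2cc1OC`: 15000 nM
- compound 3, `COc1cc2ncnc(Nc3ccc(NC(=O)c4ccccc4I)cc3)c2cc1OC`: 33000 nM

Compound 2 stands level with compound 1 at the digits shown, and together they give the lowest numbers of the three; compound 3 lies furthest from it, a 2.2-fold higher number from compound 2 to compound 3 (0.34 log units; beyond the scatter). The new compound is compound 4, `COc1cc2ncnc(Nc3ccc(NC(=O)c4cc(F)ccc4Br)cc3)c2cc1OC`, and the change from compound 2 reads (2-bromo-5-fluorophenyl in place of 4-fluorophenyl on a carbonyl carbon).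

Two measured steps speak to this change. Replacing the 4-fluorophenyl of compound 2 by 2-iodophenyl gave a 2.2-fold higher number from compound 2 to compound 3 (0.34 log units; beyond the scatter), and replacing the methyl of compound 1 by iodo gave a 2.2-fold higher number from compound 1 to compound 3 (0.34 log units; beyond the scatter). In both, placing a heavy halogen on the phenyl that sits on the carbonyl carbon went along with a modest rise in the number, meaning weaker inhibition. Compound 4 carries bromine on that same phenyl, alongside a fluorine, so a modest rise of similar size is expected in this assay, a 1.8-fold higher number from compound 2 to compound 4 (0.26 log units; within the scatter). Going by the values given here, the fluorine kept in compound 4 has no measured counterpart here, so it adds uncertainty rather than direction. Compound 4 is therefore estimated at 27000 nM, within a range from 12000 nM to 60000 nM.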

Compound 4, half-maximal inhibitory concentration: 22000 nM
Beside the measured number, compound 4's estimate is 1.2-fold (0.09 log units) above it; low and high end bracket the measured number.
By their numbers in this assay, from the lowest: compounds 1, 2, 4 and 3 (each within the scatter of the next, the first and the last beyond it).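

In this assay, the 2-bromo-5-fluorophenyl group on the carbonyl carbon cannot be told apart from any of the three earlier groups: the step of a 1.5-fold higher number from compound 2 to compound 4 (0.17 log units; within the scatter) and the step of a 1.5-fold higher number from compound 1 to compound 4 (0.17 log units; within the scatter) and the step of a 1.5-fold lower number from compound 3 to compound 4 (0.18 log units; within the scatter) all lie within the scatter. The earlier compounds shown here showed only two levels, with the step of a 2.2-fold higher number from compound 2 to compound 3 (0.34 log units; beyond the scatter) lying beyond the scatter, and compound 4 now sits within the scatter of both, so it joins neither level and blurs the line between them. A bromine on this phenyl therefore does not bring a step beyond the scatter from compound 2, and among the heavy halogens shown, only the iodine of compound 3 does; no measurement here offers an explanation for this.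

With bromine and fluorine changed together in compound 4, a phenyl carrying bromine alone would be needed to separate what each contributes. Also open, from the compounds shown here alone, is whether an amine or a carboxylic acid on this phenyl, or a longer chain in its place on the carbonyl carbon, would move the number beyond the scatter.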